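The source may hold more compounds than are shown below. What is called first, only, known or untested is meant among the compounds shown, and "the series" means these compounds.

Within the data shown here, compound 2 `N#Cc1cccc(Cn2c(=O)n(C3OC(CO)[C@@H](O)[C@H]3O)c3nc(N)nc(O)c32)c1` gives 3 uM in a functional assay (B cells) with Mus musculus as the target (on this read-out lower numbers stand for an effect already at smaller amounts and higher numbers for an effect only at larger amounts of compound), the lower of the two numbers known so far; compound 1 `Nc1nc(O)c2c(n1)n(C1OC(CO)[C@@H](O)[C@H]1O)c(=O)n2CC(O)CO` gives 45 uM. Among the measured compounds shown here, the gap between them is the only measured step, a 15-fold lower number from compound 1 to compound 2 (1.18 log units; beyond the scatter). Compound 3 `N#Cc1ccc(Cn2c(=O)n(C3OC(CO)[C@@H](O)[C@H]3O)c3nc(N)nc(O)c32)cc1` differs from compound 2 in one place: 4-cyanophenyl in place of 3-cyanophenyl on a saturated chain carbon bound to an aromatic nitrogen. For the measured compounds named here, no measured step compares a 3-cyanophenyl with a 4-cyanophenyl, and the single step concerns a different change, so it gives only weak guidance. For compound 3 the expected step is no change at the digits printed from compound 2 to compound 3 (within the scatter), an estimate of 3 uM within a range from 1 uM to 10 uM.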

Compound 3, concentration for half-maximal effect: 15 uM
The estimate for compound 3 lay 5.0-fold (0.70 log units) below the measured number, outside the stated range (above it).
By their numbers in this assay, from the lowest: compound 2; then compound 3; then compound 1.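

Exchanging 3-cyanophenyl for 4-cyanophenyl keeps the same atoms yet gives a 5.0-fold higher number from compound 2 to compound 3 (0.70 log units; beyond the scatter), so at this place it matters where the nitrile sits on the ring, not only that it is present. The 4-cyanophenyl group still compares well with 1,2-dihydroxyethyl, with a 3.0-fold lower number from compound 1 to compound 3 (0.48 log units; beyond the scatter), so part of the earlier gain remains after the shift. Nothing available explains why the two cyanophenyl groups differ. Still open, as far as these compounds go, is whether the nitrile itself is needed, which a plain phenyl would test, and how a 2-cyanophenyl would compare.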